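Swapping the aryl group at the imidazopyrazine position

This account rests on a few compounds, and the source may have more. Where it says the series, first, only, none or still open, it means among the compounds named here.

Measured compounds:
Compound 1, `O=Cc1ccc(-c2cn3ccnc3c(-c3ccc4ncn(C5CCCCC5)c4c3)n2)cc1`: 37.1%
Compound 2, `CC(=O)c1ccc(-c2cn3ccnc3c(-c3ccc4ncn(C5CCCCC5)c4c3)n2)cc1`: 18.5%

The two measured compounds share a core and differ only in the group on the carbonyl carbon. In a functional assay on UACC-62 cells (Homo sapiens) for inhibition, read by sulforhodamine B assay, with a stated time of 48 h, tested at 10 uM (a higher number here means more inhibition at the concentration tested (going by the name of the read-out), a lower number less inhibition), compound 1 gives 37.1%, and compound 2 gives 18.5%. Among the measured compounds shown here, the single step between them, a number 18.6 percentage points lower from compound 1 to compound 2 (beyond the scatter), places compound 2 at the lower of the two numbers, with compound 1 as its only neighbour and beyond the scatter of it.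

Compound 3, `c1csc(-c2cn3ccnc3c(-c3ccc4ncn(C5CCCCC5)c4c3)n2)c1`, is not yet measured. It differs from compound 2 by thiophen-2-yl in place of 4-acetylphenyl on an aromatic carbon. For the measured compounds named here, no measured step involves a thiophen-2-yl group or removes the whole 4-acetylphenyl group, so the step from compound 1 to compound 2 bears on it only in showing that a change at this position can move this assay by a modest amount. With no directional evidence, compound 3 is expected to land near the two measured values, by a step of a number 6.5 percentage points higher from compound 2 to compound 3 (within the scatter) that is estimated to fall within the scatter. Compound 3 is thus estimated at 25%, with a plausible range from 5% to 50%.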

Compound 3, a percentage reported as inhibition, at one concentration (the size of the read-out at that concentration, not a potency): 24.8%
Estimate against measurement, compound 3: 0.2 percentage points above, and the stated range covers the measured number.
By their numbers in this assay, from the lowest: compounds 2 and 3 (each within the scatter of the next); then compound 1.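

In this assay the whole 4-acetylphenyl group can be exchanged for thiophen-2-yl, a five-membered aromatic ring with a sulfur atom, and the step is a number 6.3 percentage points higher from compound 2 to compound 3 (within the scatter) so this larger change at the position leaves the reading about where it was. The same thiophen-2-yl group in place of 4-formylphenyl gives a number 12.3 percentage points lower from compound 1 to compound 3 (beyond the scatter) and this sets compound 1 apart from both other compounds, while compound 2, which also carries a carbonyl on its phenyl ring, stays with compound 3, so a carbonyl on that ring does not by itself go with the higher number. Nothing available explains these differences.

The three compounds leave open how an unsubstituted phenyl group, a thiophen-3-yl group, or a phenyl ring carrying an amine or a carboxylic acid would read at this position. With a single aldehyde-bearing example behind the highest number, they also leave open whether other small groups on the phenyl ring, such as a nitrile or a hydroxymethyl group, would read with compound 1 or with compound 2.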